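One Double Bond in a Long Chain, Potency Unchanged?

The source may hold more compounds than are shown below. What is called first, only, known or untested is meant among the compounds shown, and "the series" means these compounds.

Within the data shown here, compound 1 `CCCCCCCCCCCCCCCc1cc(=O)c2c(O)c(C)c(O)cc2o1` is the only compound here with an actual number: in a functional assay on MDA-MB-231 cells (Homo sapiens) for antiproliferative activity, read by MTT assay (a lower number here means a stronger inhibitor, a higher number a weaker inhibitor), compound 1 gives 42800 nM. Compound 2 `CCCCCCCCCCCCCCCc1cc(=O)c2c(O)c(C)c(O)c(C)c2o1` reaches only a limit in this assay, > 87000 nM (the limit of > 87000 nM in this assay, at which 1 of the 2 values shown sits). Among the measured compounds shown here, the single measured step, an at least 2.0-fold higher number from compound 1 to compound 2 (0.30 log units; that floor lies within the scatter), concerns an aromatic carbon, not the chain. Compound 3 `CCCC/C=C\CCCCCCCCCc1cc(=O)c2c(O)c(C)c(O)cc2o1` differs from compound 1 elsewhere: hex-1-en-1-yl in place of hexyl on a saturated chain carbon, nine bonds along the chain from an aromatic carbon. For the measured compounds named here, no measured step bears on this chain change, so no shift beyond the scatter is expected, giving the step of a 1.1-fold lower number from compound 1 to compound 3 (0.03 log units; within the scatter). Compound 3 is therefore estimated at 40000 nM, within 15000 nM to 100000 nM.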

Compound 3, half-maximal inhibitory concentration: 42800 nM
Beside the measured number, compound 3's estimate is 1.1-fold (0.03 log units) below it; measured number inside the range.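

In this assay the change from hexyl to hex-1-en-1-yl gives no change at the digits printed from compound 1 to compound 3 (within the scatter) and shows that, nine bonds along the chain from an aromatic carbon, one double bond can enter the chain without a shift beyond the scatter. Among these compounds, until now the only measured step concerned an aromatic carbon, so this is the first reading on the chain itself. Nothing measured here tells why the number holds.

On these data alone, whether an amine or a carboxylic acid on this chain, or a longer chain, would also leave the number in place stays open.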